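The compounds below may be only part of what the source reports. "The series", "measured", "known", "first", "only" and "open" are said of these compounds alone.

Compound 1 `C[C@H]1[C@H](NCc2ccsc2)C[C@H]2C[C@@H]1C2(C)C`: 50000 nM
Compound 2 `C[C@H]1[C@H](NCc2cc(C3CC3)cs2)C[C@H]2C[C@@H]1C2(C)C`: 25000 nM
Compound 3 `CCCCc1ccsc1CN[C@@H]1C[C@H]2C[C@@H]([C@H]1C)C2(C)C`: 25000 nM

In an ADME assay on MDCK cells (Canis lupus familiaris) for cytotoxicity, read by microscopy, with a stated time of 48 h (a lower number here means that less compound is tolerated, a higher number that more compound is tolerated), compound 1 gives 50000 nM, the largest of the three numbers shown. Compound 2 gives 25000 nM and compound 3 gives 25000 nM; each gap to compound 1 lies within the scatter of repeated measurements, so the three compounds cannot be told apart on these numbers. Compound 4 `C[C@H]1[C@H](NCc2cncs2)C[C@H]2C[C@@H]1C2(C)C` differs from compound 1 by 1,3-thiazol-5-yl in place of thiophen-3-yl on a saturated chain carbon bound to an amine nitrogen. Going by the values given here, no measured pair shows a change of this kind on its own, so the data give no measured step for it. Because compound 1 gives 50000 nM and the other two sit within the scatter of that, no step beyond the scatter is expected. Compound 4 is expected to give 50000 nM, between 25000 nM and 100000 nM. The expected step of no change at the digits printed from compound 1 to compound 4 (within the scatter) stays within the scatter.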

Compound 4, minimum cytotoxic concentration: > 100000 nM
Compound 4: no number, only a limit; the forecaster's own chance of this, stated with the estimate: 15%; middle value at least 2.0-fold (0.30 log units) away from the limit.
By their numbers in this assay, from the lowest: compounds 2, 3 and 1 (each within the scatter of the next). At a limit, above all of these: compound 4.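

In this assay compound 4 gives > 100000 nM, which is a limit and not a number. Going by these compounds alone, putting 1,3-thiazol-5-yl in place of thiophen-3-yl on a saturated chain carbon bound to an amine nitrogen is the first single change at this position, and it gives an at least 2.0-fold higher number from compound 1 to compound 4 (0.30 log units; that floor lies within the scatter). How large the step really is cannot be read past that floor: the limit of > 100000 nM in this assay, at which 1 of the 4 values shown sits.

The compounds shown leave open how a pyridin-3-yl ring or a phenyl ring would fare at this position. They also leave open whether a thiazole ring carrying a butyl chain would behave like compound 4.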